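Dimethylbenzyl Analogue in a HepG2 Cytotoxicity Series

The source may report more compounds than this note shows. Statements on the series, on what has been measured and on what is new or still open speak of the compounds shown alone.

Of the compounds shown here, three have been measured: compound 1 `COc1cccc(CNCCCNc2ccnc3cc(Cc4ccccc4)ccc23)c1O` gives 5720 nM in an ADME assay on HepG2 cells (Homo sapiens) for cytotoxicity, read by luminescence, CellTiter-Glo and ATP content, with a stated time of 72 h; on this read-out higher numbers stand for an effect only at larger amounts of compound and lower numbers for an effect already at smaller amounts; compound 2 `COc1cccc(Oc2ccc3c(NCCCNCc4cccc(OC)c4O)ccnc3c2)c1` gives 5300 nM; compound 3 `COc1cccc(CNCCCNc2ccnc3cc(Cc4ccc(C#N)cc4)ccc23)c1O` gives 7150 nM.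

Compound 3 has the highest of the three numbers, yet a 1.3-fold higher number from compound 1 to compound 3 (0.10 log units; within the scatter) and a 1.3-fold higher number from compound 2 to compound 3 (0.13 log units; within the scatter) both stay within the scatter, as does a 1.1-fold lower number from compound 1 to compound 2 (0.03 log units; within the scatter).

Compound 4 `COc1cccc(CNCCCNc2ccnc3cc(Cc4cc(C)cc(C)c4)ccc23)c1O` differs from compound 3 in one place: 3,5-dimethylphenyl in place of 4-cyanophenyl on a saturated chain carbon bound to an aromatic carbon. Going by the values given here, the steps that bear on this position, cyano in place of hydrogen and 4-cyanobenzyl in place of 3-methoxyphenoxy, were all within the scatter, so no step beyond the scatter is expected in this assay. Compound 4 is therefore estimated at 6500 nM, between 3000 nM and 14000 nM, meaning an expected 1.1-fold lower number from compound 3 to compound 4 (0.04 log units; within the scatter).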

Compound 4, half-maximal effective concentration: 2680 nM
Beside the measured number, compound 4's estimate is 2.4-fold (0.38 log units) above it; measured number outside the range, below it.
By their numbers in this assay, from the lowest: compounds 4, 2, 1 and 3 (each within the scatter of the next, the first and the last beyond it).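

In this assay, this position, on a saturated chain carbon bound to an aromatic carbon, now gives steps beyond the scatter: a 2.7-fold lower number from compound 3 to compound 4 (0.43 log units; beyond the scatter) with 3,5-dimethylphenyl in place of 4-cyanophenyl, and a 2.1-fold lower number from compound 1 to compound 4 (0.33 log units; beyond the scatter) with 3,5-dimethylphenyl in place of phenyl. Going by these compounds alone, the earlier cyano change here stayed within the scatter, so the dimethyl pattern is the first change at this position to separate compounds. Compound 4 is not set apart from every compound, however: a 2.0-fold lower number from compound 2 to compound 4 (0.30 log units; within the scatter) with 3,5-dimethylbenzyl in place of 3-methoxyphenoxy.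

Nothing measured here gives a reason for these steps. From the compounds shown here alone, whether a single methyl, an amine or a carboxylic acid on this ring would give a similar step remains open.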